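The compounds below may be only part of what the source reports. "The series", "measured", "known", "first", "only" and "open" are said of these compounds alone.

Working notes on the series. Three compounds carry numbers in an assay on isolated protein with fibroblast growth factor 2 (Homo sapiens) as the target; on this read-out lower numbers stand for tighter binding and higher numbers for weaker binding. Compound 1 `COC1C(OCc2ccccc2)C2COC(O2)C1OS(=O)(=O)O` gives 8020000 nM, compound 2 `COC1OC(C)C(OCc2ccccc2)C(OS(=O)(=O)O)C1OS(=O)(=O)O` gives 249000 nM, and compound 3 `O=S(=O)(O)OC[C@@H]1O[C@@H](O[C@H]2[C@H](OS(=O)(=O)O)[C@H](OS(=O)(=O)O)C(OS(=O)(=O)O)O[C@H]2COS(=O)(=O)O)[C@@H](OS(=O)(=O)O)[C@H](OS(=O)(=O)O)[C@H]1OS(=O)(=O)O` gives 13300 nM. Compound 3 stands lowest of the three; its nearest neighbour is compound 2, whose number lies beyond the scatter above it, and compound 1 lies further still. Within the data shown here, no pair among the measured compounds differs in one place only, so no single-change step is available in this assay.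

Compound 4 `O=S(=O)(O)OC[C@@H]1O[C@H](O[C@H]2[C@H](OS(=O)(=O)O)[C@H](OS(=O)(=O)O)C(OS(=O)(=O)O)O[C@H]2COS(=O)(=O)O)[C@@H](OS(=O)(=O)O)[C@H](OS(=O)(=O)O)[C@H]1OS(=O)(=O)O` is the next point. Relative to compound 3 the change is the two compounds have the same atoms and bonds; at least one stereo element is drawn with a configuration in one of them and without one in the other: 1 of 10 stereo elements differ; a stereocentre at a saturated ring carbon is drawn S in compound 3 and R in compound 4. With no measured pair of the same kind to lean on, the expected step is small: a change of one drawn stereocentre with all atoms and bonds kept is, on the numbers shown, expected to fall within the scatter or close to it, in no fixed direction, so the step from compound 3 to compound 4 is estimated at a 1.1-fold higher number from compound 3 to compound 4 (0.05 log units; within the scatter). Compound 4 is therefore expected to give about 15000 nM in this assay, within 5000 nM to 45000 nM.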

Compound 4, dissociation constant: 6300 nM
Beside the measured number, compound 4's estimate is 2.4-fold (0.38 log units) above it, within the range that was stated.
By their numbers in this assay, from the lowest: compound 4; then compound 3; then compound 2; then compound 1.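

In this assay the series now has its first single-change step: turning the stereocentre at a saturated ring carbon from S to R goes with a 2.1-fold lower number from compound 3 to compound 4 (0.32 log units; beyond the scatter). Among these compounds, all atoms and bonds stay the same, so the configuration drawn at this one carbon is the only difference in the pair, and it is enough for a modest step that is beyond the scatter. One point limits how far the step can be read as a true effect of configuration: the fact that one of compounds 3 and 4 is drawn with a defined configuration and the other without, at the place where they differ.

The compounds shown leave open whether the same change gives a step of similar size and direction on a core carrying a carboxylic acid or an amine. They also leave open how the other stereocentres of the core bear on the number, since only this one has been varied singly.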